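Swapping an amine tail for an acid tail on a vitamin D agonist

This account rests on a few compounds, and the source may have more. Where it says the series, first, only, none or still open, it means among the compounds named here.

Two compounds share a core built around a substituted pyrrole carrying an amide side chain. Compound 1 `CCn1c(C(=O)NCc2ccc(OC)cc2)ccc1C(CC)(CC)c1ccc(C#CC(O)(CC)CC)c(C)c1` has an amide bearing a methoxybenzyl group. In an assay on cells for agonist activity at vitamin D3 receptor (Homo sapiens), read by microscopy (a lower number here means that less compound is needed, a higher number that more compound is needed for the effect), compound 1 gives only a limit, > 50 nM, so no number is available for it. Compound 2 `CCn1cc(C(CC)(CC)c2ccc(C#CC(O)(CC)CC)c(C)c2)cc1C(=O)NCCCN(C)C` carries instead an amide to a 3-(dimethylamino)propyl chain. In this assay, going by the values given here, compound 2 gives 142 nM, which is the only number among the values shown. The value of compound 1 is a limit (the limit of > 50 nM in this assay, at which 1 of the 2 values shown sits).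

Compound 3 `CCn1cc(C(CC)(CC)c2ccc(C#CC(O)(CC)CC)c(C)c2)cc1C(=O)N[C@@H](C(=O)O)C(C)C` is the next variation on this amide. It differs from compound 2 in one place: 1-carboxy-2-methylpropyl in place of 3-(dimethylamino)propyl on an amide-type nitrogen. Among the compounds with values here, no measured pair shows what such a change does, so the expectation rests on compound 2 alone. The step from compound 2 to compound 3 is expected to be modest and toward a higher number, a 1.8-fold higher number from compound 2 to compound 3 (0.25 log units; within the scatter). Compound 3 is therefore estimated at 250 nM, with a plausible range from 60 nM to 1000 nM.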

Compound 3, half-maximal effective concentration: 68.3 nM
The estimate for compound 3 lay 3.7-fold (0.56 log units) above the measured number, within the range that was stated.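

Replacing the 3-(dimethylamino)propyl tail with the 1-carboxy-2-methylpropyl tail on the amide-type nitrogen gives, in this assay, a 2.1-fold lower number from compound 2 to compound 3 (0.32 log units; beyond the scatter). Going by these compounds alone, this is the first step that can be read at this position, and it shows that the amine at the end of the chain is not needed for activity here, since a carboxylic acid on a branched chain with a defined stereocentre does better, though only modestly so. Compound 1 gives only a limit, so no step involving it can be read: the limit of > 50 nM in this assay, at which 1 of the 3 values shown sits.

A single step cannot separate the contribution of the carboxylic acid from that of the branched carbon chain carrying it, nor say why the number falls. A plain 2-methylpropyl chain without the acid, a methyl ester in place of the acid, or the opposite arrangement at the stereocentre would each bear on that question, and none of these is among the compounds shown.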